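Replacing the carbamoyl group of compound 2

A few compounds are considered here, and "the series" means these few. Any claim that something is new, unique, unknown or untested is made for them only; others in the source may bear on it.

In an ADME assay (Fibroblast) for cytotoxicity, with Homo sapiens as the target (on this read-out higher numbers stand for weaker inhibition and lower numbers for stronger inhibition), compound 2 (`NC(=O)c1cn(COCCO)c2ncnc(N)c12`) gives only a limit, > 320000 nM, not a number. The closest measured relative is compound 1 (`Nc1ncnc2c1ccn2COCCO`), which carries hydrogen where compound 2 carries carbamoyl. In this assay compound 1 likewise gives only a limit, > 100000 nM. The step that the two limits leave unreadable from compound 1 to compound 2 therefore cannot be sized, as both ends are limits. Compound 3 (`COC(=N)c1cn(COCCO)c2ncnc(N)c12`) differs from compound 2 by a group of 4 heavy atoms (2 carbon, 1 nitrogen, 1 oxygen; no ring) in place of a group of 3 heavy atoms (1 carbon, 1 nitrogen, 1 oxygen; no ring), on an aromatic carbon. Among the measured compounds shown here, no measured step bears directly on this exchange. The evidence at hand is only that the limit of > 100000 nM in this assay, at which 1 of the 2 values shown sits, and that (the limit of > 320000 nM in this assay, at which 1 of the 2 values shown sits). With nothing pointing toward stronger inhibition, compound 3 is expected to remain at a limit, and in this assay compound 3 is estimated at 320000 nM, within a range from 100000 nM to 1000000 nM. This estimate means an expected step of a number no higher from compound 2 to compound 3 (the limit leaves the size open), none beyond the scatter.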

Compound 3, half-maximal inhibitory concentration: > 100000 nM
Compound 3: a limit, no number (the forecaster's own chance of this, stated with the estimate: 85%); the middle value is on the limit's open side.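

Compound 1, compound 2 and compound 3 all give only limits in this assay, so none of the steps among them can be read. The compounds shown leave open whether any group on this aromatic carbon would give a real number rather than a limit.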